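The compounds below may be only part of what the source reports. "The series", "measured", "known", "first", "only" and "open" are said of these compounds alone.

Compound 1 `COc1ccc(C2Cc3ccccc3C(C3=C(O)OCCC3=O)C2)cc1` carries a methoxy group on a simpler form of the shared core. In a functional assay on XF498 cells (Homo sapiens) for inhibition, with a stated time of 72 h (a higher number here means a weaker inhibitor, a lower number a stronger inhibitor), compound 1 reaches only the limit of > 10000 nM, which is not a number. Compound 2 `CC1(c2ccccc2)CC(=O)C(C2CC(c3ccc(-c4ccc(Br)cc4)cc3)Cc3ccccc32)=C(O)O1` instead bears a 4-bromophenyl group together with a methyl and a phenyl on its core, and in this assay compound 2 gives 1360 nM. Compound 3 `CCC1(c2ccccc2)CC(=O)C(C2CC(c3ccc(-c4ccc(Br)cc4)cc3)Cc3ccccc32)=C(O)O1` differs from compound 2 by one added methyl. In this assay compound 3 again reaches only the limit of > 10000 nM. The step of an at least 7.3-fold higher number from compound 2 to compound 3 (0.86 log units; beyond the scatter) therefore lies beyond the scatter, and compound 3 stands together with compound 1 at the limit described in the limit of > 10000 nM in this assay, at which 2 of the 3 values shown sit. Compound 4 `CCC1(c2ccccc2)CC(=O)C(C2CC(c3ccc(OC)cc3)Cc3ccccc32)=C(O)O1` keeps the rest of compound 3 unchanged but takes (methoxy in place of 4-bromophenyl on an aromatic carbon). Among the measured compounds shown here, no measured step covers this change; what is known is that compound 3 sits at the limit, and that compound 1, the one other methoxy compound, sits at the limit too. Compound 4 is therefore expected to remain at the limit, with an estimate of 20000 nM between 8000 nM and 60000 nM. The expected step that the limit leaves unreadable from compound 3 to compound 4 thus amounts to no change that could be resolved.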

Compound 4, half-maximal inhibitory concentration: > 10000 nM
Compound 4: only a limit was reported (the forecaster's own chance of this, stated with the estimate: 80%); the middle value lies beyond the limit too.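

Compound 3 and compound 4 both stand at a limit rather than a number in this assay, so no step between them can be read: the limit of > 10000 nM in this assay, at which 3 of the 4 values shown sit.

Left open is whether methoxy in place of 4-bromophenyl changes inhibition at all, and by how much.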